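Pyrrolidin-1-yl in Place of Butyl on the Shared Core

The compounds below may be only part of what the source reports. "The series", "measured", "known", "first", "only" and "open" are said of these compounds alone.

In a functional assay on U-251 cells (Homo sapiens) for inhibition, read by sulforhodamine B assay, with a stated time of 72 h (on this read-out higher numbers stand for an effect only at larger amounts of compound and lower numbers for an effect already at smaller amounts), compound 1 `O=C(/C=C/c1ccc([N+](=O)[O-])o1)c1ccc(Br)cc1` gives 21400 nM, compound 2 `CSc1ccc(C(=O)/C=C/c2ccc([N+](=O)[O-])o2)cc1` gives 14200 nM and compound 3 `CCCCc1ccc(C(=O)/C=C/c2ccc([N+](=O)[O-])o2)cc1` gives 3900 nM, the lowest number of the three. Compound 4 `O=C(/C=C/c1ccc([N+](=O)[O-])o1)c1ccc(N2CCCC2)cc1` keeps the shared core and differs from compound 3 in one place: pyrrolidin-1-yl in place of butyl on an aromatic carbon. Among the compounds with values here, no measured compound carries a ring at this position, so the measured steps bear on the change only indirectly. Methylsulfanyl in place of bromo gives a 1.5-fold lower number from compound 1 to compound 2 (0.18 log units; within the scatter). Butyl in place of bromo gives a 5.5-fold lower number from compound 1 to compound 3 (0.74 log units; beyond the scatter), and butyl in place of methylsulfanyl gives a 3.6-fold lower number from compound 2 to compound 3 (0.56 log units; beyond the scatter). Losing the butyl group has so far meant a modest move toward higher numbers, but pyrrolidin-1-yl itself is untested. In this assay a small step toward a higher number is therefore expected, probably no larger than those modest steps. The expected step is a 1.5-fold higher number from compound 3 to compound 4 (0.19 log units; within the scatter). For compound 4 the estimate is 6000 nM, with an expected range from 2000 nM to 18000 nM.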

Compound 4, half-maximal effective concentration: 35900 nM
Compound 4: middle estimate off by 6.0-fold (0.78 log units), on the low side; measured number outside the range, above it.
By their numbers in this assay, from the lowest: compound 3; then compounds 2, 1 and 4 (each within the scatter of the next, the first and the last beyond it).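

Within the data shown here, at this position, on an aromatic carbon para to a large group, pyrrolidin-1-yl is the first group with a ring, and in this assay it undoes what butyl had gained, with a 9.2-fold higher number from compound 3 to compound 4 (0.96 log units; beyond the scatter) as the step. Against methylsulfanyl it also moves away, with a 2.5-fold higher number from compound 2 to compound 4 (0.40 log units; beyond the scatter) as the step, while against bromo it stays close, with a 1.7-fold higher number from compound 1 to compound 4 (0.22 log units; within the scatter) as the step, so among these four groups only butyl stands clearly apart. Nothing available accounts for this result.

Still open, as far as these compounds go, is whether cyclopentyl, with a ring and no nitrogen, or diethylamino, with nitrogen and no ring, would follow compound 4 or compound 3. Also open, from the compounds shown here alone, is whether a longer chain such as hexyl would carry the butyl gain further.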